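The source may hold more compounds than are shown below. What is called first, only, known or untested is meant among the compounds shown, and "the series" means these compounds.

Measured so far:
compound 1, `CCNc1nc(/C=C/c2ccc(OC)c(OC)c2)cc(/C=C/c2ccc(OC)c(OC)c2)n1`: 38500 nM
compound 2, `COc1ccc(/C=C/c2cc(/C=C/c3ccc(OC)c(OC)c3)nc(NCCO)n2)cc1OC`: 7100 nM
compound 3, `CCCNc1nc(/C=C/c2cc(OC)c(OC)c(OC)c2)cc(/C=C/c2cc(OC)c(OC)c(OC)c2)n1`: > 100000 nM

In a functional assay on HT-29 cells (Homo sapiens) for inhibition, read by resazurin assay, with a stated time of 48 h (a lower number here means a stronger inhibitor, a higher number a weaker inhibitor), compound 1 gives 38500 nM and compound 2 gives 7100 nM. The two differ by a single change, (hydroxy in place of hydrogen on a saturated chain carbon, two bonds along the chain from a nitrogen on an aromatic ring), and the step is a 5.4-fold lower number from compound 1 to compound 2 (0.73 log units; beyond the scatter). Compound 3 shares the stilbene-like arrangement around the amine-bearing core, but the difference between its core and that of compound 1 is not broken down here. In this assay compound 3 returns only a limit, > 100000 nM, which is the upper boundary of the measurement rather than a number, as noted in the limit of > 100000 nM in this assay, at which 1 of the 3 values shown sits.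

Compound 4, `COc1cc(/C=C/c2cc(/C=C/c3cc(OC)c(OC)c(OC)c3)nc(NCCCO)n2)cc(OC)c1OC`, is not yet measured. It differs from compound 3 by hydroxy in place of hydrogen on a saturated chain carbon, three bonds along the chain from a nitrogen on an aromatic ring. Among the compounds with values here, this is the same kind of change as the one from compound 1 to compound 2, not the same one: there the hydroxy entered on a saturated chain carbon two bonds along the chain from a nitrogen on an aromatic ring, here it enters three bonds along that chain. Because the earlier step was a 5.4-fold lower number from compound 1 to compound 2 (0.73 log units; beyond the scatter), compound 4 is expected to sit somewhat below the limit seen for compound 3, so that the expected step is an at least 2.5-fold lower number from compound 3 to compound 4 (0.39 log units; beyond the scatter). Since compound 3 itself gave only a limit, the expectation for compound 4 is loose, and a further limit would not be surprising. The estimate for compound 4 in this assay is 40000 nM, between 15000 nM and 150000 nM.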

Compound 4, half-maximal inhibitory concentration: 12400 nM
For compound 4 the middle estimate is 3.2-fold (0.51 log units) above the measured one; measured number outside the range, below it.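

In this assay the hydroxy group on a saturated chain carbon, three bonds along the chain from a nitrogen on an aromatic ring, comes with an at least 8.0-fold lower number from compound 3 to compound 4 (0.90 log units; beyond the scatter), and this turns the propyl of the earlier compound into the 3-hydroxypropyl of the later one. The value of compound 3, > 100000 nM, is a limit of the assay and not a number. In the two pairs shown, the change lowers the number on both cores, which shows that its direction carried over from one core to the other, but not that its size did: the same change on two cores in this assay, a 5.4-fold lower number (0.73 log units; beyond the scatter) from compound 1 to compound 2 and an at least 8.0-fold lower number (0.90 log units; beyond the scatter) from compound 3 to compound 4; the limit leaves it open whether they differ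

The compounds shown leave open how much of each step belongs to the core and how much to the chain, as the hydroxy group sits on a 2-hydroxyethyl in compound 2 and on a 3-hydroxypropyl in compound 4, and neither chain appears with a hydroxy group on both cores. They also leave open whether an amine or a carboxylic acid at the end of the chain, or a longer chain bearing the hydroxy group, would follow the same direction in this assay.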